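Three Limits and One Chloro Swap

This account rests on a few compounds, and the source may have more. Where it says the series, first, only, none or still open, it means among the compounds named here.

- Compound 1 `C/C(=C\CC/C(C)=C/CC[C@@H]1[C@@]2(C)CCC(=O)C(C)(C)[C@H]2CC[C@@]1(C)O)CC/C=C(\C)C(=O)OCc1cn(-c2ccc(F)cc2)nn1` gives > 150000 nM (a limit)
- Compound 2 `C/C(=C\CC/C(C)=C/CC[C@@H]1[C@@]2(C)CCC(=O)C(C)(C)[C@H]2CC[C@@]1(C)O)CC/C=C(\C)C(=O)OCc1cn(-c2ccc([N+](=O)[O-])cc2)nn1` gives > 150000 nM (a limit)
- Compound 3 `C/C(=C\CC/C(C)=C/CC[C@@H]1[C@@]2(C)CCC(=O)C(C)(C)[C@H]2CC[C@@]1(C)O)CC/C=C(\C)C(=O)OCc1cn(-c2cccc([N+](=O)[O-])c2)nn1` gives > 150000 nM (a limit)

In a functional assay on A549 cells (Homo sapiens) for antiproliferative activity, read by MTT assay, with a stated time of 48 h (on this read-out higher numbers stand for weaker inhibition and lower numbers for stronger inhibition), compound 3 gives > 150000 nM as a limit of the assay, not a number. The whole series offers one firm fact: the limit of > 150000 nM in this assay, at which 3 of the 3 values shown sit, and no exact value. Compound 4 `C/C(=C\CC/C(C)=C/CC[C@@H]1[C@@]2(C)CCC(=O)C(C)(C)[C@H]2CC[C@@]1(C)O)CC/C=C(\C)C(=O)OCc1cn(-c2cccc(Cl)c2)nn1` keeps the shared core and makes one change, chloro in place of nitro on an aromatic carbon, meta to a large group (chloro in place of nitro on an aromatic carbon). The same difference can be read as 3-nitrophenyl to 3-chlorophenyl.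

Among the measured compounds shown here, three measured steps bear on this change. Nitro in place of fluoro gives a step that the two limits leave unreadable from compound 1 to compound 2 and a larger swap of the aryl group gives a step that the two limits leave unreadable from compound 1 to compound 3 in the same series. Moving to 3-nitrophenyl from 4-nitrophenyl gives a step that the two limits leave unreadable from compound 2 to compound 3 as well. None of them has a readable size, so they offer no measured size or direction to carry over. Compound 1, with a fluoro group on its aromatic ring, also gives > 150000 nM as a limit. No step beyond the scatter is therefore expected in this assay. The estimated step is a step that the limit leaves unreadable from compound 3 to compound 4 in this reading. For compound 4 the estimate is 200000 nM with an expected range from 90000 nM to 400000 nM (most likely reported only as a limit).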

Compound 4, half-maximal inhibitory concentration: 147000 nM
Compound 4: middle estimate off by 1.4-fold (0.13 log units), on the high side; the range from low to high includes it.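

In this assay, chloro in place of nitro on this aromatic carbon, meta to a large group, gives the series its first exact number, and the change reads as an at least 1.0-fold lower number from compound 3 to compound 4 (0.00 log units; that floor lies within the scatter). The comparisons with the other two aryl groups read the same way, as an at least 1.0-fold lower number from compound 2 to compound 4 (0.00 log units; that floor lies within the scatter) and an at least 1.0-fold lower number from compound 1 to compound 4 (0.00 log units; that floor lies within the scatter), so all three are only floors that hide the real size of the step and do not show that 3-chlorophenyl does better than the groups it replaces. The new fact is modest, namely that one exact value now lies close to the limit that still holds the other compounds: the limit of > 150000 nM in this assay, at which 3 of the 4 values shown sit.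

On these data alone, whether a methoxy group, an amine or a carboxylic acid on this aromatic carbon would give a step beyond the scatter remains open. As far as these compounds go, the steps among compound 1, compound 2 and compound 3 still cannot be read, so how those three would rank against one another and against compound 4 also stays unknown.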